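Second chlorine on the phenyl at an aromatic nitrogen

The source may hold more compounds than are shown below. What is called first, only, known or untested is meant among the compounds shown, and "the series" means these compounds.

Measured compounds:
Compound 1 `N#CC1=C(N)Oc2c(c3nc4ccccc4nc3c3ccccc23)C12C(=O)N(Cc1cnnn1-c1cccc(Cl)c1)c1ccccc12` gives 35200 nM in an ADME assay on L02 cells (Homo sapiens) for antiproliferative activity, read by MTT assay, with a stated time of 48 h; on this read-out lower numbers stand for stronger inhibition and higher numbers for weaker inhibition.
Compound 2 `Cc1ccc(C)c(-n2nncc2CN2C(=O)C3(C(C#N)=C(N)Oc4c3c3nc5ccccc5nc3c3ccccc43)c3ccccc32)c1` gives only a limit in this assay, namely > 50000 nM.
Compound 3 `N#CC1=C(N)Oc2c(N)cc3nc4ccccc4nc3c2C12C(=O)N(Cc1cnnn1-c1ccc(Cl)cc1)c1ccccc12` also gives only a limit in this assay, namely > 50000 nM.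

Compound 3 therefore stands at the edge of what this assay can report, at the limit of > 50000 nM in this assay, at which 2 of the 3 values shown sit. For the measured compounds named here, a limit of this kind says only that the true number lies beyond the reach of the test, not where it lies.

Compound 4 `N#CC1=C(N)Oc2c(N)cc3nc4ccccc4nc3c2C12C(=O)N(Cc1cnnn1-c1cc(Cl)ccc1Cl)c1ccccc12` differs from compound 3 in one place: 2,5-dichlorophenyl in place of 4-chlorophenyl on an aromatic nitrogen. Going by the values given here, the only measured step that touches this same position is an at least 1.4-fold higher number from compound 1 to compound 2 (0.15 log units; that floor lies within the scatter), in which a different phenyl was swapped on the same aromatic nitrogen. That step moved the number by so little that it cannot be told apart from the scatter of repeated measurements, and it ended at the limit of this assay. The change from compound 3 to compound 4 is of the same kind, a swap of the phenyl on the aromatic nitrogen, so no shift beyond the scatter is expected in either direction.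

Compound 4 is therefore expected to give about 60000 nM in this assay, within a range of 25000 nM to 150000 nM, and most likely to be reported only as a limit. The expected step is a step that the limit leaves unreadable from compound 3 to compound 4, which stays within the scatter.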

Compound 4, half-maximal inhibitory concentration: > 50000 nM
Compound 4 ended at the assay's limit; the forecaster's own chance of this, stated with the estimate: 70%; the middle value does not contradict the limit.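

For the compounds shown here, compound 3 and compound 4 both give a limit rather than a number in this assay, so no step between them can be read: the limit of > 50000 nM in this assay, at which 3 of the 4 values shown sit. The compounds shown leave open whether 2,5-dichlorophenyl in place of 4-chlorophenyl on the aromatic nitrogen changes the true number at all, and in which direction.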